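Two Chlorines Give Way to One Methyl on the Sulfonyl Arene

The compounds below may be only part of what the source reports. "The series", "measured", "known", "first", "only" and "open" are said of these compounds alone.

Measured compounds:
compound 1, `CC1CCN(c2c(S(=O)(=O)c3cc(Cl)cc(Cl)c3)cnc3ccc(Cl)cc23)CC1`: 88%
compound 2, `COc1cccc(S(=O)(=O)c2cnc3ccc(OC)cc3c2N2CCC(C)CC2)c1`: 0%

In an assay on isolated protein for displacement of a labelled ligand from metabotropic glutamate receptor 5 (Homo sapiens), with a stated time of 60 min, tested at 1 uM (on this read-out higher numbers stand for more inhibition at the one concentration tested (going by the name of the read-out) and lower numbers for less inhibition), compound 1 gives 88%, the higher of the two numbers available. Compound 2 gives 0%, a value far below it and well beyond the usual scatter. Among the measured compounds shown here, compound 1 and compound 2 differ from each other in more than one place, so no single step connects them and only their two values can be set side by side.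

Compound 3, `Cc1ccc(S(=O)(=O)c2cnc3ccc(Cl)cc3c2N2CCC(C)CC2)cc1`, has not yet been measured in this assay. It differs from compound 1 at one place only: 4-methylphenyl in place of 3,5-dichlorophenyl on a sulfonyl sulfur. For the measured compounds named here, no measured pair isolates this change, so its effect is not known from the data. The only point of reference is that the single variation of the sulfonyl aryl group seen so far, in compound 2 together with other changes, comes with 0%. On that basis a loss is expected, though a smaller one than that gap, since the rest of compound 3 matches compound 1. The expected step is a number 38 percentage points lower from compound 1 to compound 3 (beyond the scatter). For compound 3 the estimate in this assay is 50%, within 15% to 85%.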

Compound 3, a percentage reported as inhibition, at one concentration (the size of the read-out at that concentration, not a potency): 95%
Compound 3: middle estimate off by 45 percentage points, on the low side; measured number above the stated range.
By their numbers in this assay, from the lowest: compound 2; then compounds 1 and 3 (each within the scatter of the next).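

In this assay, putting 4-methylphenyl in place of 3,5-dichlorophenyl on a sulfonyl sulfur gives a number 7 percentage points higher from compound 1 to compound 3 (within the scatter), so the two compounds cannot be told apart on this read-out. This place therefore accepts an aryl group with no chlorine at all and still gives a high reading in this pair, which shows that the two chlorines are not required for that reading on this core. No supporting measurement is available to explain why these two different aryl groups read alike.

The compounds shown leave open how much more variation this place accepts, for instance a cyclohexyl ring or a longer chain such as butyl on the sulfonyl sulfur, or an aryl ring carrying a carboxylic acid or an amine. Going by these compounds, each number also comes from a single concentration and is not a potency, so it remains open whether compound 1 and compound 3 would still read alike at lower concentrations.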